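The source may report more compounds than this note shows. Statements on the series, on what has been measured and on what is new or still open speak of the compounds shown alone.

Measured so far in a physicochemical assay for solubility, in phosphate buffer; a higher number here means a more soluble compound, a lower number a less soluble compound:
- compound 1 `COc1ccc(C2=[N+]3C(=Nc4c(-c5ccccc5)c5c(n4[B-]3(F)F)-c3ccc(OCC(=O)N[C@@H](CCC(=O)O)C(=O)O)cc3CC5)C(c3ccccc3)=C2I)cc1` gives 158000 nM
- compound 2 `COc1ccc2c(c1)CCc1c(-c3ccccc3)c3n(c1-2)[B-](F)(F)[N+]1=C(c2ccc(OCC(=O)O)cc2)C(I)=C(c2ccccc2)C1=N3` gives 21800 nM
- compound 3 `COc1ccc2c(c1)CCc1c(-c3ccccc3)c3n(c1-2)[B-](F)(F)[N+]1=C(c2ccc(OCC(=O)N[C@@H](CC(=O)O)C(=O)O)cc2)C(I)=C(c2ccccc2)C1=N3` gives 115000 nM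

Compound 3 lies within the usual scatter of compound 1, while compound 2 stands clearly lower. Compound 4 `COc1ccc2c(c1)CCc1c(-c3ccccc3)c3n(c1-2)[B-](F)(F)[N+]1=C(c2ccc(OCC(=O)N[C@@H](CCC(=O)O)C(=O)O)cc2)C(I)=C(c2ccccc2)C1=N3` makes one change (carboxymethyl in place of carboxy on a saturated chain carbon, two bonds along the chain from an amide-type nitrogen and a carbonyl carbon): carboxymethyl in place of carboxy on a saturated chain carbon, two bonds along the chain from an amide-type nitrogen and a carbonyl carbon. For the measured compounds named here, no measured step makes this exact swap. The nearest one (a 5.3-fold higher number from compound 2 to compound 3 (0.72 log units; beyond the scatter)) brought in the whole (1,2-dicarboxyethyl)amino group, a far larger change. Compound 1, which also carries (1,3-dicarboxypropyl)amino, gives a similar number (158000 nM). No step beyond the scatter is therefore expected in this assay here. Compound 4 is estimated at 125000 nM with an expected range of 65000 nM to 240000 nM overall. The expected step is small (a 1.1-fold higher number from compound 3 to compound 4 (0.04 log units; within the scatter)).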

Compound 4, solubility: 110000 nM
For compound 4 the middle estimate is 1.1-fold (0.06 log units) above the measured one, and the stated range covers the measured number.
By their numbers in this assay, from the lowest: compound 2; then compounds 4, 3 and 1 (each within the scatter of the next).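

In this assay, carboxymethyl in place of carboxy on a saturated chain carbon gives a 1.0-fold lower number from compound 3 to compound 4 (0.02 log units; within the scatter), so the two chain lengths cannot be told apart at this position. Set against the acid, the whole (1,3-dicarboxypropyl)amino group gives a 5.0-fold higher number from compound 2 to compound 4 (0.70 log units; beyond the scatter), which repeats the rise seen earlier with (1,2-dicarboxyethyl)amino. Going by these compounds, whether a longer chain, or an amine in place of one carboxy, would hold the number at this level remains open. Nothing given here explains these numbers.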